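The source may hold more compounds than are shown below. What is called first, only, known or untested is meant among the compounds shown, and "the series" means these compounds.

Measured in a functional assay on HEK293 cells for agonist activity at D(4) dopamine receptor (Homo sapiens), read by FLIPR; on this read-out lower numbers stand for smaller maximal responses and higher numbers for larger maximal responses:
compound 1 `N#Cc1cccc(C(=O)NCN2CCC(c3cccc[n+]3[O-])CC2)c1` gives 69%
compound 2 `Cc1ccc(Cl)c(NC(=O)CN2CCC(c3cccc[n+]3[O-])CC2)c1Cl` gives 62%
compound 3 `CCOc1cccc(C(=O)NCN2CCC(c3cccc[n+]3[O-])CC2)c1` gives 54%

Compound 1 holds the highest of the three numbers; compound 2 lies within the scatter of it, compound 3 beyond it. Compound 4 `Cc1cc(C(=O)NCN2CCC(c3cccc[n+]3[O-])CC2)ccc1Cl` differs from compound 1 by 4-chloro-3-methylphenyl in place of 3-cyanophenyl on a carbonyl carbon. Among the compounds with values here, the only measured step on the same aromatic ring at the carbonyl carbon is a number 15 percentage points lower from compound 1 to compound 3 (beyond the scatter), a modest loss. Within the data shown here, no measured compound shows the incoming 4-chloro-3-methylphenyl group itself, so the direction rests on that single step. A modest decrease, or none beyond the scatter, is expected. The estimate for compound 4 is 60%, range 45% to 75%, meaning an expected step of a number 9 percentage points lower from compound 1 to compound 4 (within the scatter).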

Compound 4, largest response reached (reported as efficacy), in percent of the reference or control that the assay uses: 62%
The estimate for compound 4 lay 2 percentage points below the measured number; measured number inside the range.
By their numbers in this assay, from the lowest: compounds 3, 2, 4 and 1 (each within the scatter of the next, the first and the last beyond it).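

In this assay, the nitrile on the ring at the carbonyl carbon proves dispensable: 4-chloro-3-methylphenyl gives a number 7 percentage points lower from compound 1 to compound 4 (within the scatter). Of the two changes to 3-cyanophenyl at this place, only the ethoxy one, a number 15 percentage points lower from compound 1 to compound 3 (beyond the scatter), moves the response beyond the scatter, so loss of the nitrile alone does not carry that step. No supporting measurement bears on the reason for this difference.

Still open, on these data alone, is whether the chlorine or the methyl alone would hold the response at this place. Also open, as far as these compounds go, is how a carboxylic acid or a primary amine on this ring would read.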